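The source may hold more compounds than are shown below. What is called first, only, known or untested is meant among the compounds shown, and "the series" means these compounds.

Among the measured compounds shown here, in a functional assay on HepG2 cells (Homo sapiens) for antiproliferative activity, read by MTT assay, with a stated time of 24 h (a higher number here means a weaker inhibitor, a lower number a stronger inhibitor), compound 1 `COc1cc(OC)c(-c2coc3cc(OCC=C(C)C)ccc3c2=O)cc1OC` gives 280 nM and compound 2 `COc1cc(OC)c(-c2coc3cc(OCc4ccc([N+](=O)[O-])cc4)ccc3c2=O)cc1OC` gives 2500 nM as the higher of the two numbers so far. Compound 3 `COc1cc(OC)c(-c2coc3cc(OCc4ccccc4C(F)(F)F)ccc3c2=O)cc1OC` has not yet been measured. Its difference from compound 2 is 2-(trifluoromethyl)phenyl in place of 4-nitrophenyl on a saturated chain carbon bound to an oxygen on an aromatic ring and the aromatic ring of carbon only stays in both, with 2-(trifluoromethyl)phenyl in place of 4-nitrophenyl. For the measured compounds named here, the only measured step at this place is an 8.9-fold higher number from compound 1 to compound 2 (0.95 log units; beyond the scatter) and it replaced 2-methylprop-1-en-1-yl with 4-nitrophenyl, so the group here can shift the number by a modest amount. That step does not exchange one substituted phenyl for another, and the data give no direct measure of such a swap. No step beyond the scatter is therefore expected in this assay and the expectation leans only slightly towards a lower number. The estimated step is a 1.7-fold lower number from compound 2 to compound 3 (0.22 log units; within the scatter) and it stays small. For compound 3 the expected value is 1500 nM with an estimated range from 350 nM to 6000 nM in this measurement.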

Compound 3, half-maximal inhibitory concentration: 6550 nM
The estimate for compound 3 lay 4.4-fold (0.64 log units) below the measured number; measured number above the stated range.
By their numbers in this assay, from the lowest: compound 1; then compound 2; then compound 3.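

In this assay the exchange of one substituted phenyl for another, on a saturated chain carbon bound to an oxygen on an aromatic ring, is not neutral: 2-(trifluoromethyl)phenyl in place of 4-nitrophenyl gives a 2.6-fold higher number from compound 2 to compound 3 (0.42 log units; beyond the scatter) and thus shows that the choice of substituted ring counts here, not only its presence in place of 2-methylprop-1-en-1-yl. Taken from the other end, 2-(trifluoromethyl)phenyl in place of 2-methylprop-1-en-1-yl gives a 23-fold higher number from compound 1 to compound 3 (1.37 log units; beyond the scatter) and so widens what this one place can do from a modest to a large step, with 2-methylprop-1-en-1-yl still the group with the lowest number among the three. No measurement is available that would explain these differences.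

The change from 4-nitrobenzyl to 2-(trifluoromethyl)benzyl alters the substituent and its numbered place on the ring together, and the compounds shown cannot separate the two. They also leave open how an unsubstituted benzyl, a longer chain ending in an alkene, or a chain carrying an amine or a carboxylic acid would read at this place.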